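Changing the Ester Group of Compound 1

The compounds below may be only part of what the source reports. "The series", "measured", "known", "first", "only" and "open" are said of these compounds alone.

Compound 1 `CCOc1cc(NC(=O)C2(NC(=O)c3ccc4c(C5CCCC5)c(-c5ncc(Cl)cn5)n(C)c4c3)CCC2)ccc1/C=C/C(=O)OC(=O)C[C@H](O)C(=O)O` shares its core with compound 2 `CCOc1cc(NC(=O)C2(NC(=O)c3ccc4c(C5CCCC5)c(-c5ncc(Cl)cn5)n(C)c4c3)CCC2)ccc1/C=C/C(=O)OCCOc1ccccc1` and compound 3 `CCOc1cc(NC(=O)C2(NC(=O)c3ccc4c(C5CCCC5)c(-c5ncc(Cl)cn5)n(C)c4c3)CCC2)ccc1/C=C/C(=O)OCCOCCOC`; the three differ only in the group on an oxygen next to a carbonyl group. In an ADME assay (liver) for pharmacokinetics, with Liver microsome (Homo sapiens) as the target, using microsomes (on this read-out lower numbers stand for a shorter-lived compound and higher numbers for a longer-lived compound), compound 1 gives 5.57 h, the higher of the two numbers shown for this series. Compound 2 reaches only a limit of this assay, > 5 h, and the limit of > 5 h in this assay, at which 1 of the 3 values shown sits, leaves the step that the limit leaves unreadable from compound 1 to compound 2 unreadable. Compound 3 gives 0.85 h, so the step of a 6.6-fold lower number from compound 1 to compound 3 (0.82 log units; beyond the scatter) is the nearest comparison to compound 1. Compound 4 `CCOc1cc(NC(=O)C2(NC(=O)c3ccc4c(C5CCCC5)c(-c5ncc(Cl)cn5)n(C)c4c3)CCC2)ccc1/C=C/C(=O)OCC(N)=O` carries carbamoylmethyl in place of (2-carboxy-2-hydroxyethyl)carbonyl on an oxygen next to a carbonyl group. Within the data shown here, the one readable step at this position, a 6.6-fold lower number from compound 1 to compound 3 (0.82 log units; beyond the scatter), was a modest fall, while the step that the limit leaves unreadable from compound 1 to compound 2 cannot be sized, so two exchanges at the same place give one downward step and one open question. A step of a 2.8-fold lower number from compound 1 to compound 4 (0.44 log units; beyond the scatter) is therefore expected, downward and of modest size. Compound 4 is estimated at 2 h in this assay, between 0.7 h and 6 h.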

Compound 4, half-life: 0.983 h
Compound 4: middle estimate off by 2.0-fold (0.31 log units), on the high side, within the range that was stated.
By their numbers in this assay, from the lowest: compounds 3 and 4 (each within the scatter of the next); then compound 1.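

In this assay, the exchange of (2-carboxy-2-hydroxyethyl)carbonyl for carbamoylmethyl gives a 5.7-fold lower number from compound 1 to compound 4 (0.75 log units; beyond the scatter), so a second readable exchange on this oxygen falls in the same direction as the first. On the saturated chain carbon, carbamoyl and (2-methoxyethoxy)methyl cannot be told apart, with a 1.2-fold higher number from compound 3 to compound 4 (0.06 log units; within the scatter), although the two groups differ in make-up. Phenoxymethyl at that carbon goes against this shared level, since compound 2, whose value is a limit of the assay, gives an at least 5.0-fold lower number from compound 2 to compound 4 (0.70 log units; beyond the scatter).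

As far as these compounds go, the step between compound 1 and compound 2 still cannot be read: the limit of > 5 h in this assay, at which 1 of the 4 values shown sits. It remains open whether a benzyl group or a carboxymethyl group on this oxygen would stay with compound 3 and compound 4 or stand with compound 1 and compound 2.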